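Oral exposure in rat: aryl to pyridyl swap on benzylamine

The compounds below may be only part of what the source reports. "The series", "measured", "known", "first", "only" and "open" are said of these compounds alone.

Measured compounds:
- compound 1 `COc1ccccc1CNC1(CCC(C)(C)C)C(=O)C(C2=NS(=O)(=O)c3cc(NS(C)(=O)=O)ccc3N2)=C(O)c2ccccc21` — 1600 ng.h/mL in an ADME assay on the whole organism (plasma, strain Sprague-Dawley) for pharmacokinetics, with Rattus norvegicus as the target, at a dose of 5 mg/kg by the oral route; a lower number here means less compound in the circulation, a higher number more compound in the circulation at the dose given
- compound 2 `Cc1cccc(C)c1CNC1(CCC(C)(C)C)C(=O)C(C2=NS(=O)(=O)c3cc(NS(C)(=O)=O)ccc3N2)=C(O)c2ccccc21` — 3500 ng.h/mL in this assay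

Compound 2 holds the higher of the two numbers; the step of a 2.2-fold higher number from compound 1 to compound 2 (0.34 log units; beyond the scatter) is beyond the scatter, so compound 2 stands clearly above compound 1.

Compound 3 `Cc1cccc(CNC2(CCC(C)(C)C)C(=O)C(C3=NS(=O)(=O)c4cc(NS(C)(=O)=O)ccc4N3)=C(O)c3ccccc32)n1` has not been measured. It differs from compound 2 in one place: 6-methylpyridin-2-yl in place of 2,6-dimethylphenyl on a saturated chain carbon bound to an amine nitrogen. Read one bond further out, this is 2,6-dimethylbenzyl to (6-methylpyridin-2-yl)methyl.

Among the measured compounds shown here, only one measured step exists, from compound 1 to compound 2, and it compares two carbocyclic rings that differ in their substituents. It does not speak to a change of a ring carbon to a ring nitrogen, nor to a 2,6-dimethylphenyl leaving. The two measured numbers bracket a narrow window, and nothing in them points to a direction for compound 3. The expectation is therefore a step near zero, a 1.4-fold lower number from compound 2 to compound 3 (0.15 log units; within the scatter), with wide uncertainty in both directions. Compound 3 is estimated at 2500 ng.h/mL, with a range of 900 ng.h/mL to 7000 ng.h/mL.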

Compound 3, area under the concentration-time curve: 1340 ng.h/mL
Compound 3: the middle estimate sits 1.9-fold (0.27 log units) above what was measured; low and high end bracket the measured number.
By their numbers in this assay, from the lowest: compounds 3 and 1 (each within the scatter of the next); then compound 2.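

In this assay, the position on the saturated chain carbon bound to an amine nitrogen now carries a ring with a hetero atom, and 6-methylpyridin-2-yl does not hold the level of 2,6-dimethylphenyl (a 2.6-fold lower number from compound 2 to compound 3 (0.42 log units; beyond the scatter)). Set against 2-methoxyphenyl, the same ring gives no step that can be separated from the usual scatter (a 1.2-fold lower number from compound 1 to compound 3 (0.08 log units; within the scatter)), so compound 1 and compound 3 cannot be told apart, and of the three groups only 2,6-dimethylphenyl stands clear of the other two. Nothing at hand bears on what lies behind these steps, so no cause can be assigned to them.

In compound 3 a ring nitrogen enters and a methyl group leaves in the same change, and the compounds shown do not tell which of the two carries the step; a phenyl ring with a single methyl group would separate them. Also open, going by these compounds, is whether a pyridine ring with no methyl group, or one with two methyl groups, would stand with compound 3 or with compound 2 in this read-out.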